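The compounds below may be only part of what the source reports. "The series", "measured", "known", "first", "only" and "open" are said of these compounds alone.

Measured in a functional assay on HT-29 cells (Homo sapiens) for inhibition, read by MTT assay, with a stated time of 48 h; a lower number here means a stronger inhibitor, a higher number a weaker inhibitor:
compound 1 `COc1cc(-c2nnc(SC)n2-c2ccc(N(C)C)cc2)cc(OC)c1OC`: > 60000 nM, a limit
compound 2 `COc1cc(-c2nnc(SCC(=O)c3ccc(F)cc3)n2-c2ccc(N(C)C)cc2)cc(OC)c1OC`: 78100 nM

Among the compounds with values here, compound 2 holds the only true number in this assay, and the other reading is the limit of > 60000 nM in this assay, at which 1 of the 2 values shown sits. Compound 3 `COc1ccc(C(=O)CSc2nnc(-c3cc(OC)c(OC)c(OC)c3)n2-c2ccc(N(C)C)cc2)cc1O` carries 3-hydroxy-4-methoxyphenyl in place of 4-fluorophenyl on a carbonyl carbon. Within the data shown here, only one measured step bears on this change, a step that the limit leaves unreadable from compound 1 to compound 2, the step that brought in the (4-fluorophenyl)carbonyl group. It gives no size to carry over, so the data fix neither the size nor the direction of the next step in this assay. With compound 2 at 78100 nM, the expectation leans tentatively toward stronger inhibition. For compound 3, a reading that is only a limit remains possible. The estimate amounts to an expected 3.9-fold lower number from compound 2 to compound 3 (0.59 log units; beyond the scatter). For compound 3 the estimated value is 20000 nM, with an expected range of 1000 nM to 100000 nM.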

Compound 3, half-maximal inhibitory concentration: > 60000 nM
Compound 3 gave a limit, no number (the forecaster's own chance of this, stated with the estimate: 25%); at least 3.0-fold (0.47 log units) between middle value and limit.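

In this assay no new step can be read among compound 1, compound 2 and compound 3, because two of the three readings are limits and not numbers: the limit of > 60000 nM in this assay, at which 2 of the 3 values shown sit. The compounds shown leave open whether 3-hydroxy-4-methoxyphenyl in place of 4-fluorophenyl on a carbonyl carbon changes inhibition at all, and in which direction.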